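The compounds below may be only part of what the source reports. "The series", "measured", "known", "first", "only" and "open" are said of these compounds alone.

Measured in a functional assay on DU-145 cells (Homo sapiens) for antiproliferative activity, read by MTT assay, with a stated time of 48 h; on this read-out lower numbers stand for stronger inhibition and higher numbers for weaker inhibition:
- Compound 1 `C/C(=C\CC/C(C)=C/CC[C@@H]1[C@@]2(C)CCC(=O)C(C)(C)[C@H]2CC[C@@]1(C)O)CC/C=C(\C)C(=O)OCc1cn(-c2cccc(C)c2)nn1`: 137000 nM
- Compound 2 `C/C(=C\CC/C(C)=C/CC[C@@H]1[C@@]2(C)CCC(=O)C(C)(C)[C@H]2CC[C@@]1(C)O)CC/C=C(\C)C(=O)OCc1cn(-c2ccccc2Cl)nn1`: > 150000 nM, a limit and not a number

Compound 2 is known only by a limit, (the limit of > 150000 nM in this assay, at which 1 of the 2 values shown sits). Compound 3 `C/C(=C\CC/C(C)=C/CC[C@@H]1[C@@]2(C)CCC(=O)C(C)(C)[C@H]2CC[C@@]1(C)O)CC/C=C(\C)C(=O)OCc1cn(-c2cccc(C(F)(F)F)c2)nn1` carries 3-(trifluoromethyl)phenyl in place of 2-chlorophenyl on an aromatic nitrogen. Among the measured compounds shown here, one measured step bears on this change, an exchange of aryl groups on the same nitrogen. It is an at least 1.0-fold higher number from compound 1 to compound 2 (0.03 log units; that floor lies within the scatter), and its floor lies within the scatter, so it shows no real size or direction. For the measured compounds named here, the only true number nearby is that of compound 1, 137000 nM. On that basis, no step beyond the scatter is expected in this assay, and compound 3 may well return only a limit too. The expected step is an at least 1.1-fold lower number from compound 2 to compound 3 (0.06 log units; that floor lies within the scatter). The estimate for compound 3 is 130000 nM, with an expected range of 65000 nM to 250000 nM.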

Compound 3, half-maximal inhibitory concentration: > 150000 nM
Compound 3 was reported as a limit (the forecaster's own chance of this, stated with the estimate: 45%); middle value at least 1.1-fold (0.06 log units) from the limit.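

Compound 3 now stands with compound 2 as known only by a limit, and not by a number: the limit of > 150000 nM in this assay, at which 2 of the 3 values shown sit.

The step between these two limits cannot be read, so the exchange of 2-chlorophenyl for 3-(trifluoromethyl)phenyl on the aromatic nitrogen has no visible size or direction in this assay. Trifluoromethyl in place of methyl on the aromatic carbon gives an at least 1.0-fold higher number from compound 1 to compound 3 (0.03 log units; that floor lies within the scatter), and since that floor lies within the scatter, this change also shows no real effect.

On these data alone, what an amine or a carboxylic acid on the phenyl ring would do stays open, as does a longer alkyl chain in place of the aryl group on the nitrogen. As far as these compounds go, it also remains open whether a change elsewhere in the shared core would move the numbers further than any change at this position.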